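Back to a 4-Formylphenyl Group: Expecting Compound 4

The source may report more compounds than this note shows. Statements on the series, on what has been measured and on what is new or still open speak of the compounds shown alone.

Going by the values given here, in a functional assay on MCF7 cells (Homo sapiens) for inhibition, read by sulforhodamine B assay, with a stated time of 48 h, tested at 10 uM (on this read-out lower numbers stand for less inhibition and higher numbers for more inhibition at the one concentration tested (going by the name of the read-out)), compound 3 `Cc1cccc(-c2cn3ccnc3c(-c3ccc4ncn(Cc5ccccc5)c4c3)n2)c1` gives 22.2%, the lowest of the three numbers measured so far. Compound 1 `O=Cc1ccc(-c2cn3ccnc3c(-c3ccc4ncn(C5CCCCC5)c4c3)n2)cc1` gives 47.8%, and compound 2 `CCc1ccc(-c2cn3ccnc3c(-c3ccc4ncn(Cc5ccccc5)c4c3)n2)cc1` gives 58%. Compound 4 `O=Cc1ccc(-c2cn3ccnc3c(-c3ccc4ncn(Cc5ccccc5)c4c3)n2)cc1` differs from compound 3 in one place: 4-formylphenyl in place of 3-methylphenyl on an aromatic carbon. The measured step that bears on this change is a number 35.8 percentage points lower from compound 2 to compound 3 (beyond the scatter), a large loss on leaving a substituted phenyl group for 3-methylphenyl. Compound 1 carries the same 4-formylphenyl group on a core that differs elsewhere, and its value of 47.8% gives a sense of where such a group tends to land. Since the move to 3-methylphenyl cost so much, moving away from it again is expected to recover most of that loss. The expected step is a number 27.8 percentage points higher from compound 3 to compound 4 (beyond the scatter). Compound 4 is therefore estimated at 50%, with a range from 35% to 65%.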

Compound 4, a percentage reported as inhibition, at one concentration (the size of the read-out at that concentration, not a potency): 47.8%
For compound 4 the middle estimate is 2.2 percentage points above the measured one, within the range that was stated.
By their numbers in this assay, from the lowest: compound 3; then compounds 1 and 4 (each within the scatter of the next); then compound 2.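

At this position, a number 25.6 percentage points higher from compound 3 to compound 4 (beyond the scatter) and a number 10.2 percentage points lower from compound 2 to compound 4 (beyond the scatter) in this assay show that the 4-formylphenyl group recovers part, but not all, of the level reached with 4-ethylphenyl. On the aromatic nitrogen, no change at the digits printed from compound 1 to compound 4 (within the scatter) shows that benzyl and cyclohexyl read alike when 4-formylphenyl is present. Nothing available here explains these differences.

Still open, as far as these compounds go, is how an amine or a carboxylic acid would read in the place of the formyl group, and whether a 4-methylphenyl group would behave more like 4-ethylphenyl or like 3-methylphenyl.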